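The source may hold more compounds than are shown below. What is called first, only, known or untested is meant among the compounds shown, and "the series" means these compounds.

In a functional assay on SGC-7901 cells (Homo sapiens) for antiproliferative activity, read by MTT assay, with a stated time of 24 h (a lower number here means a stronger inhibitor, a higher number a weaker inhibitor), compound 1 `Cc1cccc(NNC(=O)c2ccc(NS(=O)(=O)c3cnc(O)nc3O)cc2)c1` is reported only as a limit, > 20000 nM. For the measured compounds named here, compound 2 `O=C(NNc1ccccc1F)c1ccc(NS(=O)(=O)c2cnc(O)nc2O)cc1` gives 16000 nM, the only value so far that is an actual number. Compound 3 `Cc1ccccc1NNC(=O)c1cccc(NS(=O)(=O)c2cnc(O)nc2O)c1` is likewise known only as a limit, > 20000 nM. Going by the values given here, the series so far is therefore marked by the limit of > 20000 nM in this assay, at which 2 of the 3 values shown sit.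

The next compound, compound 4 `O=C(NNc1cccc(Cl)c1)c1cccc(NS(=O)(=O)c2cnc(O)nc2O)c1`, keeps the core of compound 3 and changes one group: 3-chlorophenyl in place of 2-methylphenyl on an amine nitrogen. In words, 3-chlorophenyl stands in place of 2-methylphenyl on an amine nitrogen.

Among the compounds with values here, one measured step bears on this change, an at least 1.2-fold lower number from compound 1 to compound 2 (0.09 log units; that floor lies within the scatter). It is also an exchange of one substituted phenyl group for another on an amine nitrogen, but it sits on the core of compound 1, and neither the group leaving nor the group entering here takes part in it. Within the data shown here, with so small a step as the only guide, no step beyond the scatter is expected in this assay, and the data fix no direction. The expected step is an at least 1.1-fold lower number from compound 3 to compound 4 (0.04 log units; that floor lies within the scatter).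

Among the measured compounds shown here, the expectation stays close to the one number available, compound 2 at 16000 nM. It also stays close to the limit reached by most of the series. For compound 4 the estimated value is 18000 nM, with an expected range of 9000 nM to 30000 nM.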

Compound 4, half-maximal inhibitory concentration: 11800 nM
Beside the measured number, compound 4's estimate is 1.5-fold (0.18 log units) above it; low and high end bracket the measured number.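

On the core of compound 3, the exchange of 2-methylphenyl for 3-chlorophenyl on an amine nitrogen gives the only actual number for that core among the compounds shown: in this assay compound 4 gives 11800 nM. The change reads as an at least 1.6-fold lower number from compound 3 to compound 4 (0.22 log units; that floor lies within the scatter), which is a floor and not a size, so this pair does not establish a real difference between the two groups. Going by these compounds, the true size of the step stays unknown because compound 3 is known only through a limit, the same limit that marks much of the series: the limit of > 20000 nM in this assay, at which 2 of the 4 values shown sit.

The pair changes both the substituent and its place on the phenyl ring, so the contribution of the chlorine cannot be separated from that of its place, and a 2-chlorophenyl group on this same core would help to separate them. On these data alone, whether any group on this amine nitrogen, such as an unsubstituted phenyl or a methoxyphenyl, moves the series clearly away from the limit in this assay also remains open.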